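This account rests on a few compounds, and the source may have more. Where it says the series, first, only, none or still open, it means among the compounds named here.

Measured in a functional assay on MCF7 cells (Homo sapiens), read by MTT assay, with a stated time of 48 h; on this read-out higher numbers stand for weaker inhibition and lower numbers for stronger inhibition:
- compound 1 `CCN(CC)CCNC(=O)c1ccc(C(CC)(CC)c2ccc(OCC(=O)C(C)(C)C)c(C)c2)n1CC`: 690 nM
- compound 2 `CCn1c(C(=O)NCCN(C)C)ccc1C(CC)(CC)c1ccc(OCC(=O)C(C)(C)C)c(C)c1`: 520 nM
- compound 3 `C#CCNC(=O)c1ccc(C(CC)(CC)c2ccc(OCC(O)C(C)(C)C)c(C)c2)n1CC`: > 50000 nM

Compound 3 stands at > 50000 nM, which is a limit of this assay and not a number. Compound 4 `CC[C@@H](C)[C@H](NC(=O)c1ccc(C(CC)(CC)c2ccc(OCC(O)C(C)(C)C)c(C)c2)n1CC)C(=O)O` differs from it in one group: 1-carboxy-2-methylbutyl in place of propargyl on an amide-type nitrogen. Here 1-carboxy-2-methylbutyl takes the place of propargyl on an amide-type nitrogen. Going by the values given here, the only measured step is a 1.3-fold lower number from compound 1 to compound 2 (0.12 log units; within the scatter). Among the compounds with values here, it concerns a different group, so it bears on this replacement only weakly, and no measured step covers the replacement itself. A clear move in either direction is therefore not expected, and the expected step is a number no higher from compound 3 to compound 4 (the limit leaves the size open). For compound 4 the estimated value is 50000 nM, with an expected range from 12000 nM to 100000 nM.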

Compound 4, half-maximal inhibitory concentration: 2000 nM
The estimate for compound 4 lay 25-fold (1.40 log units) above the measured number, and the stated range ends above it.
By their numbers in this assay, from the lowest: compounds 2 and 1 (each within the scatter of the next); then compound 4. At a limit, above all of these: compound 3.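

In this assay, the group on this amide-type nitrogen clearly matters: 1-carboxy-2-methylbutyl in place of propargyl gives an at least 25-fold lower number from compound 3 to compound 4 (1.39 log units; beyond the scatter). The earlier step changed only diethylamino to dimethylamino and stayed within the scatter, so it gave no sign that a single change could move the number this far. Compound 3 stands at a limit, so the full size of this step remains unknown: the limit of > 50000 nM in this assay, at which 1 of the 4 values shown sits.

The compounds shown do not separate the carboxylic acid from the branched chain that carries it. A methyl ester or a plain sec-butyl group on this nitrogen would tell these two apart.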